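Methyl on the Aromatic Nitrogen: Two Matched Pairs

This account rests on a few compounds, and the source may have more. Where it says the series, first, only, none or still open, it means among the compounds named here.

Values in a functional assay on HT-29 cells (Homo sapiens) for inhibition; a lower number here means a stronger inhibitor, a higher number a weaker inhibitor:
compound 1 `C(=C\c1ccc2[nH]ccc2c1)\c1ccc2ccccc2c1` sits at a limit, > 5000 nM.
compound 2 `Cn1ccc2cc(/C=C\c3ccc4ccccc4c3)ccc21` sits at a limit, > 5000 nM.
compound 3 `COc1cc(/C=C/c2c[nH]c3ccccc23)cc(OC)c1OC` gives 3230 nM.

Compound 1 and compound 2 differ by methyl in place of hydrogen on an aromatic nitrogen. Both values are limits, so the step that the two limits leave unreadable from compound 1 to compound 2 has no readable size (the limit of > 5000 nM in this assay, at which 2 of the 3 values shown sit). Compound 4 `COc1cc(/C=C/c2cn(C)c3ccccc23)cc(OC)c1OC` is not yet measured in this assay; it differs from compound 3 by methyl in place of hydrogen on an aromatic nitrogen, the same kind of change, though here the place is two ring bonds from the ring atom that bears a large group. How the core of compound 3 differs from that of compound 1 is not broken down here. Within the data shown here, compound 3 holds the only number in this assay. With no measured size for this kind of change, the expected step of a 1.2-fold higher number from compound 3 to compound 4 (0.09 log units; within the scatter) is taken as small. Compound 4 is therefore expected near 4000 nM. For compound 4 the estimated range runs from 1500 nM to 12000 nM.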

Compound 4, half-maximal inhibitory concentration: 3090 nM
Compound 4: the middle estimate sits 1.3-fold (0.11 log units) above what was measured; the measured number falls inside the stated range.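

In this assay, methyl in place of hydrogen on the aromatic nitrogen gives a 1.0-fold lower number from compound 3 to compound 4 (0.02 log units; within the scatter), so on the core of compound 3 the two compounds cannot be told apart. On the core of compound 1 the same change has no readable size, since compound 1 and compound 2 both sit at a limit: the limit of > 5000 nM in this assay, at which 2 of the 4 values shown sit. The flat result therefore holds for one core only, and no measured number supports carrying it to the core of compound 1.

Open, as far as these compounds go, is whether ethyl, a longer chain or a carboxylic acid on that nitrogen would read the same on the core of compound 3. Also open, from the compounds shown here alone, is whether any such group would bring the core of compound 1 off the limit.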